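What One Fluoro Might Do to Compound 2

The source may hold more compounds than are shown below. What is called first, only, known or untested is meant among the compounds shown, and "the series" means these compounds.

In a physicochemical assay for lipophilicity, read by HPLC, in phosphate buffer, measured as octanol-water partition, at pH 7.4, tested at 100 uM (on this read-out lower numbers stand for lower lipophilicity and higher numbers for higher lipophilicity), compound 2 `O=C(O)COc1ccc(NCc2cccc(-c3ccccc3)c2)cc1F` reads 2.25 and holds the lower of the two numbers available. Its relative compound 3 `O=C(O)COc1ccc(NCc2ccc(Cl)c(-c3ccccc3)c2)cc1F` reads 2.74 on the same scale. A third relative, compound 1 `CCOc1cc(C)c(-c2cccc(COc3ccc(NCC(=O)O)c(F)c3)c2)c(C)c1` has the entry "not determined" (no result reported) here and so offers nothing to compare.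

The compound in question is compound 4 `O=C(O)COc1ccc(NCc2cccc(-c3ccccc3F)c2)cc1F` which has not yet been measured. Its difference from compound 2 is small (fluoro in place of hydrogen on an aromatic carbon) and amounts to phenyl becoming 2-fluorophenyl, a fluoro in place of hydrogen on an aromatic carbon.

Among the measured compounds shown here, only one measured step bears on this change. The step of a number 0.49 log units higher from compound 2 to compound 3 (beyond the scatter) came with a chloro in place of hydrogen on an aromatic carbon, and it is modest but beyond the scatter. That is a single case, with a different group in a different place, so it serves as a guide to direction only. For the fluoro, a smaller shift leaning the same way is expected, with no step beyond the scatter: an estimated a number 0.15 log units higher from compound 2 to compound 4 (within the scatter) for this edit. Compound 4 is therefore expected at about 2.4 with a likely range from 2.15 to 2.7 in this assay once it is measured.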

Compound 4, distribution coefficient: 2.36
Estimate against measurement, compound 4: 0.04 log units above; measured number inside the range.
By their numbers in this assay, from the lowest: compounds 2 and 4 (each within the scatter of the next); then compound 3.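

In this assay, a fluoro in place of hydrogen on an aromatic carbon, ortho to a large group, turning phenyl to 2-fluorophenyl, gives a number 0.11 log units higher from compound 2 to compound 4 (within the scatter). Among the compounds shown here, this is the first reading at this position, and it shows that this single-atom edit leaves the number inside the usual scatter, whereas the only earlier step, a number 0.49 log units higher from compound 2 to compound 3 (beyond the scatter), lay beyond it. That earlier step came with a chloro at a different place, so the two steps differ in both group and position, and the pair cannot show which of the two matters more. Nothing shown accounts for the size of either step.

The compounds shown carry no other replacement at this position, such as a chloro, a methoxy group or a nitrile, so it remains open whether any larger group here would give a step beyond the scatter. They also leave open what a fluoro would do elsewhere on the phenyl, and whether a chloro at this position would match the step seen for compound 3.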